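Ester to methylamide on the biaryl series: expectation for compound 3

The compounds below may be only part of what the source reports. "The series", "measured", "known", "first", "only" and "open" are said of these compounds alone.

Compound 1 `CCOc1ccc(-c2cccc(C(=O)OCC(F)(F)F)c2)cc1` carries a trifluoroethyl ester on the shared core and in an assay on COS-7 cells for inhibition of patatin-like phospholipase domain-containing protein 2 (Mus musculus) (on this read-out lower numbers stand for stronger inhibition and higher numbers for weaker inhibition), compound 1 gives 120000 nM. Compound 2 `CCOc1ccc(-c2cccc(C(=O)OCCOCCOC)c2)cc1` carries the longer ether chain on the same ester oxygen. In this assay compound 2 reaches only a limit, > 200000 nM, so compound 2 stands at the limit of > 200000 nM in this assay, at which 1 of the 2 values shown sits, and its true number is not known. The step of an at least 1.6-fold higher number from compound 1 to compound 2 (0.22 log units; that floor lies within the scatter) is therefore a floor and not a measured size.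

Compound 3 `CCOc1ccc(-c2cccc(C(=O)NC)c2)cc1` is the next change: methylamino in place of 2-(2-methoxyethoxy)ethoxy on a carbonyl carbon. For the measured compounds named here, the one measured step, from compound 1 to compound 2, concerns only the chain on the ester oxygen and does not cover the exchange of the ester oxygen itself for an amide nitrogen, so it gives only a weak guide. Both measured compounds sit at weak inhibition, and no shown step points to a change beyond the scatter for this assay. Compound 3 is estimated at 150000 nM, within 50000 nM to 400000 nM, with a fair chance that the assay again reports only a limit. That estimate for compound 3 means the step of an at least 1.3-fold lower number from compound 2 to compound 3 (0.12 log units; that floor lies within the scatter) from the limit of compound 2, expected to be no more than a modest move and not beyond the scatter.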

Compound 3, half-maximal inhibitory concentration: > 200000 nM
Compound 3: only a limit was reported; the forecaster's own chance of this, stated with the estimate: 45%; middle value at least 1.3-fold (0.12 log units) from the limit.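

In this assay compound 3 gives > 200000 nM, which is a limit of the assay and not a number. This is the first change shown on the carbonyl carbon itself rather than on the chain of the ester oxygen, and methylamino in place of 2,2,2-trifluoroethoxy gives an at least 1.6-fold higher number from compound 1 to compound 3 (0.22 log units; that floor lies within the scatter), so the amide shows no sign of stronger inhibition, though the size of the step remains unknown. The step between the other two compounds cannot be read, and the ether ester and the methylamide cannot be ordered, leaving compound 1 as the only compound with a measured number: the limit of > 200000 nM in this assay, at which 2 of the 3 values shown sit.

With a single measured number in the series, the compounds shown do not tell whether any group on this carbonyl carbon can bring inhibition into the readable range of the assay. A carboxylic acid on the same carbon, or a longer chain on the amide nitrogen, would test whether the amide series can give a measured number that can be compared with compound 1.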